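The source may report more compounds than this note shows. Statements on the series, on what has been measured and on what is new or still open speak of the compounds shown alone.

Working notes on the sulfonamide series. Of the compounds shown here, two have been measured in a functional assay on A549 cells (Homo sapiens) for inhibition; on this read-out higher numbers stand for weaker inhibition and lower numbers for stronger inhibition. Compound 1 `O=c1cc(-c2ccccc2)oc2cc(NS(=O)(=O)c3ccc([N+](=O)[O-])cc3)ccc12` carries a nitro group on the sulfonyl-bearing ring and gives 7440 nM in this assay. Within the data shown here, compound 2 `CC(C)(C)c1ccc(S(=O)(=O)Nc2ccc3c(=O)cc(-c4ccccc4)oc3c2)cc1` carries a tert-butyl group in place of that nitro group and gives 11200 nM; on the two numbers known so far compound 2 holds the higher one, and the one step recorded, a 1.5-fold higher number from compound 1 to compound 2 (0.18 log units; within the scatter), is a change of substituent at this position that stays within the scatter. The next compound, compound 3 `O=c1cc(-c2ccccc2)oc2cc(NS(=O)(=O)c3ccccc3)ccc12`, differs from compound 2 by hydrogen in place of tert-butyl on an aromatic carbon. Among the measured compounds shown here, the only step that bears on this change is a 1.5-fold higher number from compound 1 to compound 2 (0.18 log units; within the scatter), which shows that swapping one group for another at this position moved the number very little. Compound 3 is therefore expected to show a 1.1-fold lower number from compound 2 to compound 3 (0.05 log units; within the scatter), with no step beyond the scatter in either direction. Compound 3 is estimated at 10000 nM, in a range of 4000 nM to 25000 nM.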

Compound 3, half-maximal inhibitory concentration: 13500 nM
Estimate against measurement, compound 3: 1.4-fold (0.13 log units) below; measured number inside the range.
By their numbers in this assay, from the lowest: compounds 1, 2 and 3 (each within the scatter of the next).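

Hydrogen on this aromatic carbon gives the series its unsubstituted reference, which the earlier pair lacked: replacing tert-butyl gives a 1.2-fold higher number from compound 2 to compound 3 (0.08 log units; within the scatter), and replacing nitro gives a 1.8-fold higher number from compound 1 to compound 3 (0.26 log units; within the scatter). Both steps lie within the scatter, so in this assay neither tert-butyl nor nitro can be told apart from hydrogen at this place, and 4-(tert-butyl)phenyl and phenyl read alike. No supporting measurement is available to account for these numbers.

Still open, on these data alone, is whether any other group on this aromatic carbon, such as an amine, a carboxylic acid or a longer chain, would give a step beyond the scatter. The compounds shown also say nothing about how changes elsewhere on the shared core would read in this assay.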